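The source may hold more compounds than are shown below. What is called first, only, known or untested is meant among the compounds shown, and "the series" means these compounds.

Compound 1 `COC(=O)[C@H](C)NC(=O)c1ccc(Oc2nc3ccccc3nc2C)cc1` carries a methyl on a saturated chain carbon bound to an amide-type nitrogen and a carbonyl carbon. In a functional assay on MCF7 cells (Homo sapiens) for antiproliferative activity, read by MTT assay, with a stated time of 48 h (a lower number here means a stronger inhibitor, a higher number a weaker inhibitor), compound 1 gives 38400 nM. Compound 2 `CC[C@@H](C)[C@H](NC(=O)c1ccc(Oc2nc3ccccc3nc2C)cc1)C(=O)OC` differs from it in one place, (sec-butyl in place of methyl on a saturated chain carbon bound to an amide-type nitrogen and a carbonyl carbon), and in this assay compound 2 gives 36100 nM. That single change made a step of a 1.1-fold lower number from compound 1 to compound 2 (0.03 log units; within the scatter), so the two numbers are not told apart here.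

Compound 3 `CCCCCCCCCCCCNc1nc2ccccc2nc1Oc1ccc(C(=O)N[C@@H](C)C(=O)OC)cc1` has a different core, and the difference between the core of compound 3 and the core of compound 1 is not broken down here. In this assay compound 3 gives 33800 nM, a number within the scatter of both compound 2 and compound 1.

Compound 4 `CCCCCCCCCCCCNc1nc2ccccc2nc1Oc1ccc(C(=O)N[C@H](C(=O)OC)[C@H](C)CC)cc1` is the still unmeasured partner of compound 3, with the same change as before, (sec-butyl in place of methyl on a saturated chain carbon bound to an amide-type nitrogen and a carbonyl carbon), made on the core of compound 3. Since the place is described in identical words, the change is the same one.

For compound 4 the expected step is a 1.0-fold lower number from compound 3 to compound 4 (0.01 log units; within the scatter), which rests on the earlier step of a 1.1-fold lower number from compound 1 to compound 2 (0.03 log units; within the scatter) being within the scatter and on the value of compound 3 being 33800 nM. Compound 4 is therefore estimated to give 33000 nM in this assay, with a plausible range from 15000 nM to 72000 nM.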

Compound 4, half-maximal inhibitory concentration: 43300 nM
The estimate for compound 4 lay 1.3-fold (0.12 log units) below the measured number, within the range that was stated.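

In this assay the change of sec-butyl in place of methyl, now made on the core of compound 3, gave a 1.3-fold higher number from compound 3 to compound 4 (0.11 log units; within the scatter) and so leaves the two numbers not told apart. Set beside the same change on the core of compound 1, this step does not differ from the earlier one: the same change on two cores in this assay, a 1.1-fold lower number (0.03 log units; within the scatter) from compound 1 to compound 2 and a 1.3-fold higher number (0.11 log units; within the scatter) from compound 3 to compound 4, 1.4-fold (0.13 log units) apart, within the scatter of two such steps. On these two cores, then, the change left the number within the scatter both times, and the two steps agree; this does not show that an effect carries from one core to the other, as neither step is large enough to be told from the scatter, and two pairs of compounds give no rule for the wider series.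

The compounds shown leave open whether another group on the same saturated chain carbon, such as a benzyl group, an amine or a longer chain, would give a step beyond the scatter on either core. They also leave open what a carboxylic acid in place of the methyl ester would do to the number in this assay on these cores.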